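The source may hold more compounds than are shown below. What is called first, only, known or untested is meant among the compounds shown, and "the series" means these compounds.

Measured in a functional assay on PC-3 cells (Homo sapiens) for cytotoxicity, read by MTT assay, with a stated time of 72 h; a higher number here means a weaker inhibitor, a lower number a stronger inhibitor:

Compound 1 `CNC(=O)c1cc(Oc2ccc(C(=O)/C=C/c3cccc(Br)c3)cc2)ccn1` gives 3400 nM
Compound 2 `CNC(=O)c1cc(Oc2ccc(C(=O)/C=C/c3ccc(Br)cc3)cc2)ccn1` gives 18500 nM
Compound 3 `CNC(=O)c1cc(Oc2ccc(C(=O)/C=C/c3ccc([N+](=O)[O-])cc3)cc2)ccn1` gives 11100 nM

Compound 1 has the lowest number of the three, which makes it the strongest inhibitor so far. Compound 4 `CNC(=O)c1cc(Oc2ccc(C(=O)/C=C/c3ccc(C#N)cc3)cc2)ccn1` has not been measured yet. It differs from compound 1 by one change: 4-cyanophenyl in place of 3-bromophenyl on a double-bonded chain carbon bound to a double-bonded chain carbon.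

Two measured steps replace the same 3-bromophenyl. With 4-bromophenyl there is a 5.4-fold higher number from compound 1 to compound 2 (0.74 log units; beyond the scatter), and with 4-nitrophenyl there is a 3.3-fold higher number from compound 1 to compound 3 (0.51 log units; beyond the scatter). Those two compounds barely separate, with a 1.7-fold lower number from compound 2 to compound 3 (0.22 log units; within the scatter). Going by the values given here, no measured compound carries 4-cyanophenyl, so a similar rise in this assay is only an expectation. The estimate means a 3.8-fold higher number from compound 1 to compound 4 (0.58 log units; beyond the scatter). For compound 4 the estimated value is 13000 nM, with an expected range from 5500 nM to 30000 nM.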

Compound 4, half-maximal inhibitory concentration: 3870 nM
Compound 4: middle estimate off by 3.4-fold (0.53 log units), on the high side, outside the stated range (below it).
By their numbers in this assay, from the lowest: compounds 1 and 4 (each within the scatter of the next); then compounds 3 and 2 (each within the scatter of the next).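

In this assay, the rise seen with the earlier 4-substituted phenyl groups does not hold for every such group, since 4-cyanophenyl stays level with 3-bromophenyl (a 1.1-fold higher number from compound 1 to compound 4 (0.06 log units; within the scatter)). The outcome here depends on the group carried by the phenyl ring, with cyano in place of nitro giving a 2.9-fold lower number from compound 3 to compound 4 (0.46 log units; beyond the scatter), and cyano in place of bromo giving a 4.8-fold lower number from compound 2 to compound 4 (0.68 log units; beyond the scatter). No available evidence accounts for this difference among the groups.

The compounds shown leave open how a phenyl ring carrying an amine or a carboxylic acid would behave here, and whether 3-cyanophenyl would match 4-cyanophenyl.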